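Acyl-pyrrole series: from compound 2 to compound 3

The source may hold more compounds than are shown below. What is called first, only, known or untested is meant among the compounds shown, and "the series" means these compounds.

Compound 1 `COc1ccc(-c2cn(C(=O)c3ccccc3)cc2-c2ccc(OC)cc2)cc1` and compound 2 `COc1ccc(C(=O)n2cc(-c3ccc(OC)cc3)c(-c3ccc(OC)cc3)c2)cc1` share the same core and differ by a methoxy in place of hydrogen on an aromatic carbon. In an ADME assay on HeLa cells (Homo sapiens) for inhibition, read by MTT assay, with a stated time of 60 h (a lower number here means a stronger inhibitor of growth, a higher number a weaker inhibitor of growth), compound 1 gives > 100000 nM, which is a limit of the assay and not a number. In this assay compound 2 gives > 100000 nM, again a limit rather than a number. The step that the two limits leave unreadable from compound 1 to compound 2 is therefore not readable in either direction, and the limit of > 100000 nM in this assay, at which 2 of the 2 values shown sit, is the whole of the evidence so far: both values shown sit at that limit.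

Compound 3 `COc1ccc(CCC(=O)n2cc(-c3ccc(OC)cc3)c(-c3ccc(OC)cc3)c2)cc1` carries the change (2-(4-methoxyphenyl)ethyl in place of 4-methoxyphenyl on a carbonyl carbon). Among the measured compounds shown here, no measured step bears on this change, since the single step recorded is unreadable, so nothing gives a size or a direction for it in this assay. With compound 2 standing only at a limit, compound 3 is expected to stand at the same limit in this assay, giving an estimated 100000 nM within 30000 nM to 300000 nM. The expected step of a number no higher from compound 2 to compound 3 (the limit leaves the size open) is thus no change beyond the scatter, with a reported number unlikely.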

Compound 3, concentration for 50% growth inhibition: > 100000 nM
Compound 3 ended at the assay's limit (the forecaster's own chance of this, stated with the estimate: 75%); the middle value lies on the limit itself.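

In this assay compound 3 gives > 100000 nM, a limit of the assay and not a number. No step linking compound 3 to compound 1 or compound 2 can be read: the limit of > 100000 nM in this assay, at which 3 of the 3 values shown sit.

The compounds shown leave open the size and direction of both the methoxy change and the 2-(4-methoxyphenyl)ethyl change in this assay.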